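This account rests on a few compounds, and the source may have more. Where it says the series, first, only, none or still open, it means among the compounds named here.

Compound 1 `Cc1c(NC(=O)CN2C(=O)S/C(=C\c3ccc(Br)cc3)C2=O)c(=O)n(-c2ccccc2)n1C` and compound 2 `Cc1c(NC(=O)CN2C(=O)S/C(=C\c3ccc(Cl)cc3)C2=O)c(=O)n(-c2ccccc2)n1C` share the same core and differ only in one halogen on an aromatic ring. In a functional assay on MCF7 cells (Homo sapiens) for inhibition, read by MTT assay, with a stated time of 48 h (a higher number here means a weaker inhibitor, a lower number a stronger inhibitor), compound 1 gives 24100 nM and compound 2 gives 42600 nM. Chloro in place of bromo on an aromatic carbon amounts to a 1.8-fold higher number from compound 1 to compound 2 (0.25 log units; within the scatter). Repeat measurements could differ this much by chance, so compound 2 cannot be told apart from compound 1, the only other compound measured so far.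

`Cc1cc(C)c(/C=C2\SC(=O)N(CC(=O)Nc3c(C)n(C)n(-c4ccccc4)c3=O)C2=O)c(C)c1` Compound 3 keeps the core of compound 2 but exchanges the aromatic group: 2,4,6-trimethylphenyl in place of 4-chlorophenyl on a double-bonded chain carbon bound to a double-bonded ring carbon. In words, this is 2,4,6-trimethylphenyl in place of 4-chlorophenyl on a double-bonded chain carbon bound to a double-bonded ring carbon.

Going by the values given here, the halogen swap is the only measured step that bears on this change, and it is a weak guide, as no measured compound carries methyl groups on that ring. The data therefore suggest no direction, and no step beyond the scatter is expected in this assay. The expected step is a 1.4-fold lower number from compound 2 to compound 3 (0.15 log units; within the scatter). Compound 3 is estimated at 30000 nM, with an expected range from 10000 nM to 90000 nM.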

Compound 3, half-maximal inhibitory concentration: 71100 nM
Compound 3: the middle estimate sits 2.4-fold (0.37 log units) below what was measured; low and high end bracket the measured number.
By their numbers in this assay, from the lowest: compounds 1, 2 and 3 (each within the scatter of the next, the first and the last beyond it).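

In this assay, going by these compounds alone, 2,4,6-trimethylphenyl at this position, on a double-bonded chain carbon bound to a double-bonded ring carbon, gives the first step in this small set that lies beyond the scatter: 4-bromophenyl giving way to it means a 3.0-fold higher number from compound 1 to compound 3 (0.47 log units; beyond the scatter) and counts as modest. Set against 4-chlorophenyl, the same group gives a 1.7-fold higher number from compound 2 to compound 3 (0.22 log units; within the scatter) and so cannot be told apart from it, which means the change registers against only one of two halogen compounds that themselves cannot be separated. The position thus tolerates a ring with no halogen and three methyl groups without a large shift in the number, and nothing at hand explains the result.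

Still open, from the compounds shown here alone, is how a ring carrying a single methyl group would compare with the three methyl groups of compound 3, which would show whether one methyl group is enough to give the same number. Also open is how this position would respond to a ring bearing an amine or a carboxylic acid, since every ring shown here carries only halogen or methyl groups.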